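A few compounds are considered here, and "the series" means these few. Any claim that something is new, unique, unknown or untested is made for them only; others in the source may bear on it.

Measured so far in an ADME assay on HCT-116 cells (Homo sapiens) for cytotoxicity, read by MTT assay, with a stated time of 72 h; on this read-out lower numbers stand for stronger inhibition and higher numbers for weaker inhibition:
compound 1 `COc1ccc(NC(=O)c2cccc(/C=C3\CC(=O)N(c4ccccc4)C3=O)c2)cc1`: > 100000 nM, a limit
compound 2 `CCc1cccc(NC(=O)c2cccc(/C=C3\CC(=O)N(Cc4ccccc4)C3=O)c2)c1`: 80600 nM
compound 3 `COc1ccc(NC(=O)c2cccc(/C=C3\CC(=O)N(c4ccc(C)cc4)C3=O)c2)cc1`: > 100000 nM, a limit

Compound 3 stands at a limit of this assay, > 100000 nM. Compound 1 likewise gives only a limit there. The step that the two limits leave unreadable from compound 1 to compound 3 is therefore unreadable, which the limit of > 100000 nM in this assay, at which 2 of the 3 values shown sit, makes plain. Compound 4 `CCc1cccc(NC(=O)c2cccc(/C=C3\CC(=O)N(c4ccc(C)cc4)C3=O)c2)c1` differs from compound 3 by 3-ethylphenyl in place of 4-methoxyphenyl on an amide-type nitrogen. Going by the values given here, no measured step makes this same change; compound 2, which carries the 3-ethylphenyl amide with a benzyl group on the imide nitrogen, gives a weak value of 80600 nM in this assay. The change from compound 3 is therefore expected to give a number no higher from compound 3 to compound 4 (the limit leaves the size open), with no readable size. Compound 4 is estimated at 100000 nM, between 40000 nM and 300000 nM, and a limit rather than a number is about as likely as not.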

Compound 4, half-maximal inhibitory concentration: 41500 nM
For compound 4 the middle estimate is 2.4-fold (0.38 log units) above the measured one, and the stated range covers the measured number.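

In this assay, going by these compounds alone, the amide-type nitrogen gives the first readable change: 3-ethylphenyl in place of 4-methoxyphenyl gives an at least 2.4-fold lower number from compound 3 to compound 4 (0.38 log units; beyond the scatter). With 3-ethylphenyl held in place, 4-methylphenyl in place of benzyl on an amide-type nitrogen in a ring gives a 1.9-fold lower number from compound 2 to compound 4 (0.29 log units; within the scatter). The full size of the first step stays open, because compound 3 gives only a limit: the limit of > 100000 nM in this assay, at which 2 of the 4 values shown sit.

The compounds shown do not separate the effect of adding ethyl from that of removing methoxy. Also open, on these data alone, is how a longer chain, an amine or a carboxylic acid on that phenyl would read.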